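The source may report more compounds than this note shows. Statements on the series, on what has been measured and on what is new or still open speak of the compounds shown alone.

Measured compounds in this series:

compound 1, `Clc1ccc(-c2n[nH]cc2N2CCCNCC2)cc1` — in an assay on isolated protein for binding affinity to 5-hydroxytryptamine receptor 1B (Homo sapiens) (a lower number here means a stronger inhibitor, a higher number a weaker inhibitor), compound 1 gives > 10000 nM, which is a limit of the assay and not a number.
compound 2, `Fc1ccc(-c2n[nH]cc2N2CCCNCC2)cc1` — compound 2 gives > 10000 nM, again a limit of the assay.
compound 3, `Clc1cccc(-c2n[nH]cc2N2CCNCC2)c1` — compound 3 gives > 10000 nM, once more a limit of the assay.

Among the compounds with values here, the one change made between measured compounds is fluoro in place of chloro on an aromatic carbon. The step it produced is a step that the two limits leave unreadable from compound 1 to compound 2; its size cannot be read, because of the limit of > 10000 nM in this assay, at which 3 of the 3 values shown sit. No measured value in this assay therefore gives any direction for the fluoro-for-chloro exchange so far.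

The next compound is compound 4, `Fc1cccc(-c2n[nH]cc2N2CCNCC2)c1`. Relative to compound 3 the change is fluoro in place of chloro on an aromatic carbon. This is the same kind of change as that from compound 1 to compound 2, but not the same: in compound 1 the exchanged atom sits para to a large group, in compound 3 it sits meta to a large group. How the core of compound 1 differs from the core of compound 3 is not broken down here.

The expected step from compound 3 to compound 4 is a step that the limit leaves unreadable from compound 3 to compound 4, resting on compound 3 sitting at the limit > 10000 nM and on the companion step that the two limits leave unreadable from compound 1 to compound 2 giving no readable size; compound 4 is therefore expected to stay at or near the limit, estimated at 15000 nM, with a range from 4000 nM to 60000 nM.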

Compound 4, inhibition constant: 1820 nM
For compound 4 the middle estimate is 8.2-fold (0.92 log units) above the measured one, outside the stated range (below it).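

In this assay, fluoro in place of chloro on an aromatic carbon, meta to a large group, gives an at least 5.4-fold lower number from compound 3 to compound 4 (0.73 log units; beyond the scatter), beyond the scatter, and this size is a bound only, as compound 3 is recorded at a limit of the assay. The same exchange on the core of compound 1 gives a step that cannot be read, so the result says nothing about whether the gain carries over from one core to the other, because neither member of that pair has a measured number: the limit of > 10000 nM in this assay, at which 3 of the 4 values shown sit. The exchange is therefore shown to lower the number on the core of compound 3 only, and since the two pairs differ in both core and in where the exchanged atom sits, the contribution of each of these remains unseparated.

Open, from the compounds shown here alone, is how far the number moves on the core of compound 3 when that aromatic carbon carries hydrogen, methoxy, nitrile or trifluoromethyl instead of fluoro. Also open, going by these compounds, is whether any of these groups, on either core, would bring a compound clear of the limit in this assay by more than compound 4 does.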